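Chloro-substituted analogue of compound 1 in factor X assay

The compounds below may be only part of what the source reports. "The series", "measured", "known", "first", "only" and "open" are said of these compounds alone.

Compound 1, `O=C1[C@@H](NS(=O)(=O)c2cc3cccnc3s2)CCN1Cc1cc2cc[nH]cc-2n1`, was tested in an assay on isolated protein for inhibition of coagulation factor X (Oryctolagus cuniculus), tested at 0.5 uM (a higher number here means more inhibition at the concentration tested (going by the name of the read-out), a lower number less inhibition), where compound 1 gives 43%. Of the three compounds measured, compound 1 has the lowest number. Compound 2, `Cc1c(S(=O)(=O)N[C@H]2CCN(CCNc3ccncc3)C2=O)sc2cc(Cl)ccc12`, gives 47% in this assay, a number within the scatter of that of compound 1, so the two cannot be told apart. Compound 3, `O=C1[C@@H](NS(=O)(=O)c2cc3ccc(Cl)cc3s2)CCN1Cc1cc2[nH]cccc-2n1`, gives 64% in this assay, a number beyond the scatter above compound 1.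

Compound 4, `O=C1[C@@H](NS(=O)(=O)c2cc3ccnc(Cl)c3s2)CCN1Cc1cc2cc[nH]cc-2n1`, has not yet been measured. It differs from compound 1 in one place: a group of 10 heavy atoms (7 carbon, 1 nitrogen, 1 sulfur, 1 chlorine; one five-membered aromatic ring with 1 hetero atom, one six-membered aromatic ring with 1 hetero atom) in place of a group of 9 heavy atoms (7 carbon, 1 nitrogen, 1 sulfur; one five-membered aromatic ring with 1 hetero atom, one six-membered aromatic ring with 1 hetero atom), on a sulfonyl sulfur. Among the measured compounds shown here, no pair among the measured compounds differs in just one place, so no measured step guides the expectation; the data only show that compound 3, which carries a chlorine on its bicyclic group, gives 64%.

On this basis compound 4 is expected to show a small rise over compound 1, with the step of a number 9 percentage points higher from compound 1 to compound 4 (within the scatter) estimated to lie within the scatter. The estimate for compound 4 in this assay is 52%, with a range from 35% to 70%.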

Compound 4, a percentage reported as inhibition, at one concentration (the size of the read-out at that concentration, not a potency): 48%
The estimate for compound 4 lay 4 percentage points above the measured number, within the range that was stated.
By their numbers in this assay, from the lowest: compounds 1, 2 and 4 (each within the scatter of the next); then compound 3.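

With the pair of compound 1 and compound 4, there is now a single-place comparison for the group on the sulfonyl sulfur. In this assay, putting the chlorine-bearing group in place of the group without chlorine gives a number 5 percentage points higher from compound 1 to compound 4 (within the scatter), so the two compounds cannot be told apart at the concentration tested. This one pair therefore shows no readable effect of this chlorine on the shared core, and nothing available bears on the reason for that result.

On these data alone, whether a methyl group, a methoxy group or an amine in place of the chlorine would give a step beyond the scatter remains open. Also open, as far as these compounds go, is whether compound 1 and compound 4 would still be indistinguishable in a full potency measurement rather than a reading at one concentration.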